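Removing one methoxy from the shared core

A few compounds are considered here, and "the series" means these few. Any claim that something is new, unique, unknown or untested is made for them only; others in the source may bear on it.

Compound 1 `COc1cc(-c2cc(/C=C/C(=O)c3ccc(N)cc3)[nH]n2)cc(OC)c1OC` and compound 2 `COc1cc(-c2cc(/C=C/C(=O)c3ccc(Cl)c(Cl)c3)[nH]n2)cc(OC)c1OC` share the same core and differ only in the aryl group on the carbonyl carbon. Going by the values given here, in a functional assay on NCI-H23 cells (Homo sapiens) for cytotoxicity, read by sulforhodamine B assay, with a stated time of 48 h, tested at 0.01 uM (a higher number here means a weaker effect of the compound at the concentration tested, a lower number a stronger effect), compound 1 gives 102% and compound 2 gives 95%; the one recorded step, a number 7 percentage points lower from compound 1 to compound 2 (within the scatter), lies within the scatter. Compound 1 thus stands highest of the two numbers, with compound 2 its nearest neighbour, but the two are not separated beyond the scatter, and both read close to no effect at this concentration.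

Compound 3 `COc1ccc(-c2cc(/C=C/C(=O)c3ccc(N)cc3)[nH]n2)cc1OC` is not yet measured. It departs from compound 1 by hydrogen in place of methoxy on an aromatic carbon. Among the compounds with values here, no measured step touches this part of the molecule: the single step available concerns the group on the carbonyl carbon and was small. For compound 3 in this assay the expected step is a number 2 percentage points lower from compound 1 to compound 3 (within the scatter), meaning none beyond the scatter, as nothing recorded shows the remaining groups on this ring moving the read-out. Compound 3 is estimated at 100%, with an expected range from 88% to 112%.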

Compound 3, a percentage reported as activity, at one concentration (the size of the read-out at that concentration, not a potency): 103%
Compound 3: middle estimate off by 3 percentage points, on the low side; measured number inside the range.
By their numbers in this assay, from the lowest: compounds 2, 1 and 3 (each within the scatter of the next).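

In this assay, hydrogen in place of methoxy on an aromatic carbon, ortho to a methoxy group and meta to a large group, gives a number 1 percentage points higher from compound 1 to compound 3 (within the scatter), so this position now has a measured step of its own, and that step lies within the scatter. Going by these compounds alone, with the 4-aminophenyl group kept on the carbonyl carbon, compound 3 gives 103% and reads alike with compound 1, so at this single concentration the methoxy at this position is not needed to hold the read-out where it stands, although both compounds sit close to no effect and this pair can say little about the group's role under conditions where an effect appears. No evidence on hand accounts for this result.

From the compounds shown here alone, it remains open whether the step stays this small with the 3,4-dichlorophenyl group on the carbonyl carbon, or at concentrations where the compounds have a clear effect. Also open, going by these compounds, is how a hydroxy group, an ethoxy group or a fluorine atom at this position would read.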